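Benzyl aryl substitution on a shared core, cytotoxicity in cells

The source may report more compounds than this note shows. Statements on the series, on what has been measured and on what is new or still open speak of the compounds shown alone.

Measured compounds:
compound 1 `N[C@H]1CC[C@H](Nc2c(C(=O)NCc3cccc(C(F)(F)F)c3)nc(Br)c3cccnc23)CC1` with 4200 nM
compound 2 `N[C@H]1CC[C@H](Nc2c(C(=O)NCc3ccc(Cl)cc3Cl)nc(Br)c3cccnc23)CC1` with 5800 nM
compound 3 `COc1ccc(CNC(=O)c2nc(Br)c3cccnc3c2N[C@H]2CC[C@H](N)CC2)cc1` with 5000 nM

All three were tested in a functional assay on MDA-MB-435 cells (Homo sapiens) for cytotoxicity, read by MTT assay, with a stated time of 72 h (on this read-out lower numbers stand for stronger inhibition and higher numbers for weaker inhibition), and all differ only in the aryl group on the benzyl carbon bound to the amide-type nitrogen. Compound 3 gives the second highest of the three numbers; the step of a 1.2-fold lower number from compound 2 to compound 3 (0.06 log units; within the scatter) and the step of a 1.2-fold higher number from compound 1 to compound 3 (0.08 log units; within the scatter) both lie within the scatter, as does a 1.4-fold higher number from compound 1 to compound 2 (0.14 log units; within the scatter). The series therefore shows no separation between the aryl variants at this position.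

Compound 4 `N[C@H]1CC[C@H](Nc2c(C(=O)NCc3ccccc3)nc(Br)c3cccnc23)CC1` is not yet measured. It differs from compound 3 by hydrogen in place of methoxy on an aromatic carbon. The three measured steps all concern the same aryl group, and none of them moved the number beyond the scatter, so the removal of the methoxy is expected to behave similarly. The step of no change at the digits printed from compound 3 to compound 4 (within the scatter) is therefore expected to stay within the scatter, with no clear direction. Compound 4 is estimated at 5000 nM, in a range of 2500 nM to 10000 nM.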

Compound 4, half-maximal inhibitory concentration: 7000 nM
The estimate for compound 4 lay 1.4-fold (0.15 log units) below the measured number; the range from low to high includes it.
By their numbers in this assay, from the lowest: compounds 1, 3, 2 and 4 (each within the scatter of the next).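

In this assay the methoxy group could be removed altogether, leaving an unsubstituted phenyl ring, and the change gives a 1.4-fold higher number from compound 3 to compound 4 (0.15 log units; within the scatter) and so does not separate the two compounds. Among these compounds, the unsubstituted ring adds the reference that the earlier compounds lacked, and the comparisons with the other aryl groups give a 1.2-fold higher number from compound 2 to compound 4 (0.08 log units; within the scatter) and a 1.7-fold higher number from compound 1 to compound 4 (0.22 log units; within the scatter), so across these four compounds neither the 2,4-dichlorophenyl nor the 3-(trifluoromethyl)phenyl group stands apart from phenyl either. No measurement offers an explanation for how closely these numbers lie.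

The compounds shown leave open whether a carboxylic acid or an amine on the aryl ring, or a longer chain in place of the benzyl carbon, would move the number beyond the scatter. They also say nothing about changes elsewhere on the shared core, which stays the same throughout.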